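Lengthening a Methyl to Ethyl on the Shared Core

A few compounds are considered here, and "the series" means these few. Any claim that something is new, unique, unknown or untested is made for them only; others in the source may bear on it.

Compound 1 `CCC(=O)N[C@@H]1CCCc2c1cncc2N1C(=O)c2ccc(Cl)cc2[C@@H]1C` is the starting point. For the measured compounds named here, in an ADME assay on cells for inhibition of cytochrome P450 11B1, mitochondrial (Homo sapiens), read by HTRF (a lower number here means a stronger inhibitor, a higher number a weaker inhibitor), compound 1 gives 414 nM, the second highest of the three numbers measured so far. The nearest neighbour is compound 2 `CC(=O)N[C@@H]1CCCc2c1cncc2N1C(=O)c2ccc(Cl)cc2[C@@H]1C`, which gives 81 nM; the step of a 5.1-fold lower number from compound 1 to compound 2 (0.71 log units; beyond the scatter) comes from swapping hydrogen in place of methyl on a saturated chain carbon bound to a carbonyl carbon. Going by the values given here, the furthest is compound 3 `CC1(C)c2cc(Cl)ccc2C(=O)N1c1cccnc1`, which gives 4280 nM; no single-point step joins it to compound 1, so its number stands on its own.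

Compound 4 `CCC(=O)N[C@@H]1CCCc2c1cncc2N1C(=O)c2ccc(Cl)cc2[C@@H]1CC` differs from compound 1 by methyl in place of hydrogen on a saturated chain carbon bound to a saturated ring carbon. Among the compounds with values here, the only measured step, from compound 1 to compound 2, alters a different part of the molecule, the chain next to the carbonyl, and so does not speak to this change. Within the data shown here, no measured pair varies only the group on the saturated chain carbon bound to the saturated ring carbon. With nothing to guide direction, the expectation is for little or no change beyond the scatter, with the range kept wide. Compound 4 is therefore estimated to give about 500 nM, expected between 180 nM and 1400 nM, an expected step of a 1.2-fold higher number from compound 1 to compound 4 (0.08 log units; within the scatter).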

Compound 4, half-maximal inhibitory concentration: 345 nM
For compound 4 the middle estimate is 1.4-fold (0.16 log units) above the measured one; measured number inside the range.
By their numbers in this assay, from the lowest: compound 2; then compounds 4 and 1 (each within the scatter of the next); then compound 3.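

Going from methyl to ethyl at the saturated chain carbon bound to a saturated ring carbon gives (a 1.2-fold lower number from compound 1 to compound 4 (0.08 log units; within the scatter)) in this assay, so the two compounds cannot be told apart in this measurement. For the compounds shown here, this is the first measured change at this position, and it shows that, on the core of compound 1, one added methyl here leaves the number within the usual scatter. Going by these compounds alone, the only other single change available behaves differently: hydrogen in place of methyl on a saturated chain carbon bound to a carbonyl carbon gives (a 5.1-fold lower number from compound 1 to compound 2 (0.71 log units; beyond the scatter)), which lies beyond the scatter, so on this evidence the number responds to that change but not to the one at the new position. Nothing measured here accounts for this difference between the two positions.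

A single step cannot show how much room this position allows, so a longer chain such as propyl, a cyclopropyl ring or an amine here could behave quite differently. On these data alone, it also remains open whether the same methyl-to-ethyl change would read alike on compound 2.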